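Sulfonamide nitrogen substituent trimmed to methyl

The source may report more compounds than this note shows. Statements on the series, on what has been measured and on what is new or still open speak of the compounds shown alone.

Compound 3 `Cc1ccc(S(=O)(=O)NC(C)C)cc1C#Cc1cc(Cl)ccc1OCC(=O)O` is compared with compound 1 `COCCN(C)S(=O)(=O)c1ccc(C)c(C#Cc2cc(Cl)ccc2OCC(=O)O)c1` and compound 2 `Cc1ccc(S(=O)(=O)N(C)CC(C)C)cc1C#Cc1cc(Cl)ccc1OCC(=O)O`, three compounds sharing one core and differing only in the group on the sulfonamide nitrogen. In an assay on CHO cells for displacement of a labelled ligand from prostaglandin D2 receptor 2 (Homo sapiens), read by scintillation counting (a lower number here means a stronger inhibitor, a higher number a weaker inhibitor), compound 3 gives 3.4 nM. In this assay compound 1 gives 4.1 nM. In this assay compound 2 gives 4.2 nM. The steps among these three, a 1.2-fold lower number from compound 1 to compound 3 (0.08 log units; within the scatter), a 1.2-fold lower number from compound 2 to compound 3 (0.09 log units; within the scatter) and a 1.0-fold higher number from compound 1 to compound 2 (0.01 log units; within the scatter), all stay within the scatter, so the numbers of compound 3 and its two neighbours are not separated by the assay.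

Compound 4 `CNS(=O)(=O)c1ccc(C)c(C#Cc2cc(Cl)ccc2OCC(=O)O)c1` continues the same kind of variation: methyl in place of isopropyl on a sulfonamide nitrogen. The three measured steps are the only ones that bear on it, and each was within the scatter; nothing among them indicates that changing the group on the sulfonamide nitrogen moves the number. The expected step of a 1.3-fold higher number from compound 3 to compound 4 (0.12 log units; within the scatter) is therefore none beyond the scatter. Compound 4 is estimated at 4.5 nM in this assay, with a range from 1.5 nM to 14 nM.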

Compound 4, inhibition constant: 10 nM
Estimate against measurement, compound 4: 2.2-fold (0.35 log units) below; the range from low to high includes it.
By their numbers in this assay, from the lowest: compounds 3, 1 and 2 (each within the scatter of the next); then compound 4.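

Among these compounds, the sulfonamide nitrogen does respond to its substituent in this assay: methyl in place of isopropyl gives a 2.9-fold higher number from compound 3 to compound 4 (0.47 log units; beyond the scatter), the first step at this position to lie beyond the scatter, though a modest one. The same separation appears against the two compounds whose nitrogen carries a methyl plus a longer group, with a 2.4-fold higher number from compound 2 to compound 4 (0.38 log units; beyond the scatter) and a 2.4-fold higher number from compound 1 to compound 4 (0.39 log units; beyond the scatter), so among these four compounds, only the one with methyl as the sole substituent stands apart. No available data bear on the reason for this separation.

An ethyl group on the sulfonamide nitrogen would show whether the number already rises short of methyl. Also open, as far as these compounds go, are the plain amino group and the dimethylamino group on the sulfonyl sulfur, the latter testing whether a second methyl restores the lower number.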